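A few compounds are considered here, and "the series" means these few. Any claim that something is new, unique, unknown or untested is made for them only; others in the source may bear on it.

Of the compounds shown here, three built on one shared core have been measured in an assay on CHO cells for agonist activity at 5-hydroxytryptamine receptor 1D (Homo sapiens), read by GTPgammaS binding; on this read-out higher numbers stand for an effect only at larger amounts of compound and lower numbers for an effect already at smaller amounts. Compound 1 `NC(=O)OC[C@H](NC1CCN(CCCc2c[nH]c3ccc(-n4cnnc4)cc23)CC1)c1ccccc1` gives 9.3 nM. Compound 2 `CN(Cc1ccsc1)C1CCN(CCCc2c[nH]c3ccc(-n4cnnc4)cc23)CC1` gives 4.2 nM in this assay. Compound 3 `O[C@@H]1Cc2ccccc2[C@H]1NC1CCN(CCCc2c[nH]c3ccc(-n4cnnc4)cc23)CC1` gives 13 nM in this assay, the highest of the three numbers: its nearest neighbour is compound 1, with a 1.4-fold higher number from compound 1 to compound 3 (0.15 log units; within the scatter), a step inside the scatter, and its furthest is compound 2, with a 3.1-fold higher number from compound 2 to compound 3 (0.49 log units; beyond the scatter), a modest step beyond the scatter.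

Compound 4 `CC(CO)(NC1CCN(CCCc2c[nH]c3ccc(-n4cnnc4)cc23)CC1)c1ccccc1` has not yet been measured. It differs from compound 3 in one place: 1-(hydroxymethyl)-1-phenylethyl in place of 2-hydroxy-2,3-dihydro-1H-inden-1-yl on an amine nitrogen. Among the compounds with values here, the one measured step that alters the same amine substituent is a 1.4-fold higher number from compound 1 to compound 3 (0.15 log units; within the scatter), which stayed within the scatter; the group entering in compound 4, like the group leaving, carries one hydrogen-bond donor, one hydrogen-bond acceptor and one six-membered aromatic ring of carbon only. The step of a 1.1-fold higher number from compound 3 to compound 4 (0.03 log units; within the scatter) is therefore expected to remain within the scatter. The estimate for compound 4 in this assay is 14 nM, between 5 nM and 40 nM.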

Compound 4, half-maximal effective concentration: 3.4 nM
For compound 4 the middle estimate is 4.1-fold (0.61 log units) above the measured one, outside the stated range (below it).
By their numbers in this assay, from the lowest: compounds 4 and 2 (each within the scatter of the next); then compounds 1 and 3 (each within the scatter of the next).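

In this assay, putting 1-(hydroxymethyl)-1-phenylethyl in place of 2-hydroxy-2,3-dihydro-1H-inden-1-yl on the amine nitrogen gives a 3.8-fold lower number from compound 3 to compound 4 (0.58 log units; beyond the scatter) and shows that two groups with the same counts of heavy atoms, donors and acceptors are not interchangeable here, though only the group leaving has the five-membered non-aromatic ring and the defined stereocentres. The same group in place of 2-(carbamoyloxy)-1-phenylethyl gives a 2.7-fold lower number from compound 1 to compound 4 (0.44 log units; beyond the scatter) and so, unlike the earlier step at this nitrogen, shows a change beyond the scatter from that group. Set against methyl((thiophen-3-yl)methyl)amino on the saturated ring carbon, (1-(hydroxymethyl)-1-phenylethyl)amino gives a 1.2-fold lower number from compound 2 to compound 4 (0.09 log units; within the scatter) and cannot be told apart from it. No evidence is available that bears on the reason for these steps. The compounds shown leave open whether a methoxymethyl or aminomethyl group in place of the hydroxymethyl would hold the number of compound 4.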